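This account rests on a few compounds, and the source may have more. Where it says the series, first, only, none or still open, it means among the compounds named here.

Measured in an ADME assay on HEK293 cells (Homo sapiens) for cytotoxicity, with a stated time of 72 h; a higher number here means that more compound is needed for the effect, a lower number that less compound is needed:
- compound 1 `O=C(O)COc1cc(Cl)c(C(=O)Nc2cccc(-c3nc4ccccc4s3)c2)cc1[N+](=O)[O-]`: > 25000 nM
- compound 2 `O=C(Nc1ccc(O)c(-c2nc3ccccc3s2)c1)c1cc([N+](=O)[O-])ccc1Cl`: > 25000 nM

Within the data shown here, both entries are limits of the assay, not numbers, so the series so far stands at a single mark: the limit of > 25000 nM in this assay, at which 2 of the 2 values shown sit. For compound 2 the reading is likewise only a limit, > 25000 nM.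

Compound 3 `O=C(Nc1cccc(-c2nc3ccccc3s2)c1)c1cc([N+](=O)[O-])ccc1Cl` differs from compound 2 by one change: hydrogen in place of hydroxy on an aromatic carbon. This puts hydrogen in place of hydroxy on an aromatic carbon, ortho to a 1,3-benzothiazol-2-yl group.

Among the measured compounds shown here, no measured step gives a size for this change. In this assay the expected outcome is therefore a number no higher from compound 2 to compound 3 (the limit leaves the size open), with no step beyond the usual scatter and no favoured direction. For compound 3 the estimated value is 25000 nM, with an expected range from 12000 nM to 40000 nM. A reading that is again only a limit is the likeliest outcome.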

Compound 3, half-maximal effective concentration: > 27000 nM
Compound 3 gave a limit, no number; the forecaster's own chance of this, stated with the estimate: 75%; at least 1.0-fold (0.03 log units) between middle value and limit.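

In this assay compound 3 gives > 27000 nM, again a limit and not a number. The steps to it from compound 1 and compound 2 therefore cannot be read. The compounds shown leave open at what concentration any of them reaches the half-maximal effect.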